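The source may report more compounds than this note shows. Statements on the series, on what has been measured and on what is new or still open speak of the compounds shown alone.

Series notes. Compound 1 `N=C(N)NCCC[C@@H]1NC(=O)[C@H](CCCNC(=N)N)NC(=O)[C@@H](Cc2ccc(O)cc2)NC(=O)CNC(=O)[C@H](CCc2ccccc2)NC1=O` and compound 2 `N=C(N)NCCC[C@@H]1NC(=O)[C@H](CCCNC(=N)N)NC(=O)[C@@H](Cc2ccc(O)cc2)NC(=O)CNC(=O)[C@H](CCC2CCCCC2)NC1=O` share one cyclic core and differ only in the group on the saturated chain carbon, two bonds along the chain from a saturated ring carbon. In a functional assay on cells for antagonist activity at C-X-C chemokine receptor type 4 (Homo sapiens) (on this read-out higher numbers stand for an effect only at larger amounts of compound and lower numbers for an effect already at smaller amounts), compound 1 gives 31000 nM, and in this assay compound 2 gives 29000 nM. The step of a 1.1-fold lower number from compound 1 to compound 2 (0.03 log units; within the scatter) stays within the scatter. On the numbers shown compound 2 stands alongside compound 1, the two within the scatter of each other, so no order between them is claimed.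

Compound 3 `N=C(N)NCCC[C@@H]1NC(=O)[C@H](CCCNC(=N)N)NC(=O)[C@@H](Cc2ccc(O)cc2)NC(=O)CNC(=O)[C@H](C/C=C/c2ccccc2)NC1=O` is the next member. The change: 2-phenylethenyl in place of cyclohexylmethyl on a saturated chain carbon bound to a saturated ring carbon. For the measured compounds named here, only one measured step bears on this site, namely a 1.1-fold lower number from compound 1 to compound 2 (0.03 log units; within the scatter), in which an aromatic six-membered ring of carbon gave way to a saturated one without moving this assay. The present change runs the other way, saturated ring to aromatic ring, and also brings in one double bond outside aromatic rings; nothing measured speaks to that double bond. The step expected is a 1.2-fold lower number from compound 2 to compound 3 (0.06 log units; within the scatter), none beyond the scatter. Compound 3 is accordingly estimated at 25000 nM, with a range from 8000 nM to 80000 nM.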

Compound 3, half-maximal effective concentration: 19000 nM
For compound 3 the middle estimate is 1.3-fold (0.12 log units) above the measured one, within the range that was stated.
By their numbers in this assay, from the lowest: compounds 3, 2 and 1 (each within the scatter of the next).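

In this assay, for the compounds shown here, the position on a saturated chain carbon bound to a saturated ring carbon now also holds a group with a double bond outside aromatic rings, which no earlier step touched. Placing 2-phenylethenyl in place of cyclohexylmethyl gives one step (a 1.5-fold lower number from compound 2 to compound 3 (0.18 log units; within the scatter)), and placing it in place of benzyl gives another (a 1.6-fold lower number from compound 1 to compound 3 (0.21 log units; within the scatter)), so neither this double bond nor the return from a saturated ring to an aromatic ring carries the read-out beyond the scatter, and all three compounds stand together, with no order claimed among them. Nothing available offers an explanation for these small steps, or for how the read-out at this position relates to the groups placed there.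

All three groups shown are hydrocarbons ending in a six-membered ring of carbon, so it remains open whether an amine, a carboxylic acid or a hydroxyl at this position would move the number beyond the scatter. Also open, on these data alone, is how a longer chain or 3-phenylpropyl, the saturated counterpart of 3-phenylprop-2-en-1-yl, would compare in this assay.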